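Phenyl for propyl on compound 2

A few compounds are considered here, and "the series" means these few. Any claim that something is new, unique, unknown or untested is made for them only; others in the source may bear on it.

In a physicochemical assay for lipophilicity, measured as octanol-water partition (a lower number here means a more polar compound, a higher number a more lipophilic compound), compound 2 (`CCCc1cn(C/C=C(/C)CCC=C(C)C)nn1`) gives 4.05, the lowest of the three numbers. Compound 1 (`CCCc1cn(C/C=C(\C)CCC=C(C)C)nn1`) gives 4.5, and compound 3 (`CCCc1cn(C/C=C(/C)CC/C=C(\C)CCC=C(C)C)nn1`) gives 6.5. Compound 4 (`CC(C)=CCC/C(C)=C\Cn1cc(-c2ccccc2)nn1`) carries phenyl in place of propyl on an aromatic carbon. Neither measured step changes that group, so both bear on it only loosely. The step of a number 0.45 log units lower from compound 1 to compound 2 (beyond the scatter) comes with the fact that compounds 1 and 2 differ only in the configuration as drawn. The large step of a number 2.45 log units higher from compound 2 to compound 3 (beyond the scatter) accompanies 3-methylbut-2-en-1-yl in place of hydrogen on the chain. Against that step, a smaller upward move is expected in this assay. The expected step is a number 0.45 log units higher from compound 2 to compound 4 (beyond the scatter). Compound 4 is estimated at 4.5, within a range of 3.95 to 5.1.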

Compound 4, partition coefficient: 4.91
Estimate against measurement, compound 4: 0.41 log units below; low and high end bracket the measured number.
By their numbers in this assay, from the lowest: compound 2; then compound 1; then compound 4; then compound 3.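

In this assay, phenyl in place of propyl on this aromatic carbon gives a number 0.86 log units higher from compound 2 to compound 4 (beyond the scatter). Among the compounds shown, this step alone changes the group on the aromatic carbon, and it is smaller than the change on the chain: a number 2.45 log units higher from compound 2 to compound 3 (beyond the scatter). Nothing given here accounts for the phenyl step. The compounds shown do not separate the aromatic ring of phenyl from its larger count of carbon. A cyclohexyl group, a hexyl chain, an amine or a carboxylic acid on this aromatic carbon remains an open case.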